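This account rests on a few compounds, and the source may have more. Where it says the series, first, only, none or still open, it means among the compounds named here.

Measured compounds in a functional assay on CCRF-CEM cells (Homo sapiens) for antiproliferative activity, with a stated time of 72 h; a higher number here means a weaker inhibitor, a lower number a stronger inhibitor:
compound 1, `Cc1cccc(CNc2ncnc3c2ncn3[C@@H]2O[C@H](CO)[C@@H](O)[C@H]2O)c1`, gives 19100 nM.
compound 2, `COc1ccccc1CNc1ncnc2c1ncn2[C@@H]1O[C@H](CO)[C@@H](O)[C@H]1O`, gives 3200 nM.
compound 3, `COc1cc(CNc2ncnc3c2ncn3[C@@H]2O[C@H](CO)[C@@H](O)[C@H]2O)cc(OC)c1`, gives only a limit of the assay, > 166000 nM.

Compound 1 carries the highest of the two numbers in this assay; its nearest neighbour is compound 2, with a 6.0-fold lower number from compound 1 to compound 2 (0.78 log units; beyond the scatter). Compound 3 sits at the limit, (the limit of > 166000 nM in this assay, at which 1 of the 3 values shown sits), so only a bound is known for it.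

Compound 4, `Cc1ccc(O)c(CNc2ncnc3c2ncn3[C@@H]2O[C@H](CO)[C@@H](O)[C@H]2O)c1`, is not yet measured. It differs from compound 1 as follows: hydroxy in place of hydrogen on an aromatic carbon. The change sits on the benzyl ring, at the position that in compound 2 carries the methoxy group, and the methyl group of compound 1 is kept.

For the measured compounds named here, two measured steps bear on this change. The step of a 6.0-fold lower number from compound 1 to compound 2 (0.78 log units; beyond the scatter) shows that an oxygen-bearing substituent at this position is tolerated and gives a lower number. The step of an at least 8.6-fold higher number from compound 1 to compound 3 (0.93 log units; beyond the scatter) and the step of an at least 51-fold higher number from compound 2 to compound 3 (1.71 log units; beyond the scatter) show that two methoxy groups elsewhere on the ring push the number up to the limit. Going by the values given here, the hydroxy group differs from methoxy, so the analogy is loose, but the nearest precedent points toward a lower number in this assay for compound 4, likely of modest size. The estimated step is a 2.4-fold lower number from compound 1 to compound 4 (0.38 log units; beyond the scatter). Compound 4 is therefore expected to give about 8000 nM in this assay, with a range from 3000 nM to 25000 nM.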

Compound 4, half-maximal inhibitory concentration: 1900 nM
For compound 4 the middle estimate is 4.2-fold (0.62 log units) above the measured one; measured number outside the range, below it.
By their numbers in this assay, from the lowest: compounds 4 and 2 (each within the scatter of the next); then compound 1. At a limit, above all of these: compound 3.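

In this assay, hydroxy in place of hydrogen on an aromatic carbon, ortho to a large group and para to a methyl group, gives a 10-fold lower number from compound 1 to compound 4 (1.00 log units; beyond the scatter) with the methyl group kept, so this position takes a free hydroxy as well as the methoxy group seen earlier. Exchanging the 2-methoxyphenyl group for the 2-hydroxy-5-methylphenyl group gives a 1.7-fold lower number from compound 2 to compound 4 (0.23 log units; within the scatter), so these two groups cannot be told apart in this assay, and the lower number at this position does not depend on the methoxy group alone. The large gap to the 3,5-dimethoxyphenyl group, an at least 87-fold lower number from compound 3 to compound 4 (1.94 log units; beyond the scatter), is only a bound, since its starting value is a limit of the assay and not a number: the limit of > 166000 nM in this assay, at which 1 of the 4 values shown sits.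

The part played by the methyl group stays open, as no pair shown separates its contribution from that of the hydroxy group on this ring. An amine or a carboxylic acid on the same aromatic carbon would show whether an oxygen-linked group is needed there, and nothing shown indicates how either would read in this assay.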